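This account rests on a few compounds, and the source may have more. Where it says the series, first, only, none or still open, it means among the compounds named here.

Of the compounds shown here, three built on the same core have been measured in an in vitro ADME assay on microsomes from liver (Mus musculus) for pharmacokinetics, read by LC-MS, with a stated time of 10 min, tested at 1 uM; on this read-out lower numbers stand for slow clearance and higher numbers for fast clearance. Compound 1 `COc1ccc(NC(=O)[C@H]2CN(C)C[C@@H]2c2ccc(/C=C/C(=O)Nc3ccccc3N)cc2)cc1` gives 54 mL/min/kg, compound 2 `CN1C[C@H](C(=O)Nc2ccc(C#N)cc2)[C@@H](c2ccc(/C=C/C(=O)Nc3ccccc3N)cc2)C1` gives 35 mL/min/kg, and compound 3 `CN1C[C@H](C(=O)Nc2ccc(Br)cc2)[C@@H](c2ccc(/C=C/C(=O)Nc3ccccc3N)cc2)C1` gives 16 mL/min/kg, the lowest of the three numbers. Changing the group on an aromatic carbon moved the read-out modestly in two steps: a 3.4-fold lower number from compound 1 to compound 3 (0.53 log units; beyond the scatter) and a 2.2-fold lower number from compound 2 to compound 3 (0.34 log units; beyond the scatter). Compound 4 `CN1C[C@H](C(=O)Nc2ccc(F)c(Br)c2)[C@@H](c2ccc(/C=C/C(=O)Nc3ccccc3N)cc2)C1` differs from compound 3 by 3-bromo-4-fluorophenyl in place of 4-bromophenyl on an amide-type nitrogen. For the measured compounds named here, no measured step adds a fluorine while the bromine stays, so the two modest swaps are the only guide, and neither speaks to this change directly. The step is therefore expected to be no change at the digits printed from compound 3 to compound 4 (within the scatter), none beyond the scatter. Compound 4 is estimated at 16 mL/min/kg, with a range from 8 mL/min/kg to 32 mL/min/kg.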

Compound 4, clearance: 43 mL/min/kg
Estimate against measurement, compound 4: 2.7-fold (0.43 log units) below; the whole stated range lies below it.
By their numbers in this assay, from the lowest: compound 3; then compounds 2, 4 and 1 (each within the scatter of the next).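

In this assay, the low number of compound 3 does not survive this change on the amide-type nitrogen: 3-bromo-4-fluorophenyl in place of 4-bromophenyl gives a 2.7-fold higher number from compound 3 to compound 4 (0.43 log units; beyond the scatter), so keeping a bromine on this phenyl does not by itself keep the number low. The other two steps, a 1.2-fold higher number from compound 2 to compound 4 (0.09 log units; within the scatter) and a 1.3-fold lower number from compound 1 to compound 4 (0.10 log units; within the scatter), both lie within the scatter, so compound 4 cannot be told apart from compound 1 or compound 2. Nothing available explains the rise.

Still open, on these data alone, is whether the added fluorine or the changed place of the bromine carries the rise, and how a chlorine or methyl group on this phenyl would read.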